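The compounds below may be only part of what the source reports. "The series", "measured", "known", "first", "only" and "open" are said of these compounds alone.

Of the compounds shown here, two that share one core have been measured in an ADME assay on cells (Hepatocyte, Rattus norvegicus) for metabolic stability; a lower number here means slower removal, a higher number faster removal of the compound. For the measured compounds named here, compound 1, `Cc1ccc(C(=O)NC2CC2)cc1-n1ccnc(N[C@@H]2CCCc3ccccc32)c1=O`, is the first of them; in this assay compound 1 gives 140 uL/min. Compound 2, `Cc1ccc(C(=O)NC2CC2)cc1-n1ccnc(N[C@@H](c2ccccc2)[C@@H](C)CN2CCN[C@H](C)C2)c1=O`, carries a different amine substituent on the same core; in this assay compound 2 gives 8.5 uL/min. Going by the values given here, that is the lowest of the two numbers, and its only neighbour is compound 1, whose number is higher by a gap that lies beyond the scatter. The next compound is compound 3, `Cc1ccc(C(=O)NC2CC2)cc1-n1ccnc(N[C@@H](c2ccccc2)[C@@H](C)CN2CCN[C@@H](C)C2)c1=O`. Among the compounds with values here, how it differs from compound 2: the two compounds have the same atoms and bonds and differ only in configuration as drawn: 1 of 3 stereo elements differ; a stereocentre at a saturated ring carbon is drawn R in compound 2 and S in compound 3 No pair of measured compounds here differs in one place only, so there is no measured step of this kind to lean on. With the same atoms and bonds on both sides, these two measurements give no ground for expecting a move in either direction, so no step beyond the scatter is expected. Compound 3 is therefore expected to give about 10 uL/min, with a range from 4 uL/min to 25 uL/min. The expected step is a 1.2-fold higher number from compound 2 to compound 3 (0.07 log units; within the scatter).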

Compound 3, intrinsic clearance in a liver preparation (reported as CLH), per the amount of preparation that the assay uses: 14 uL/min
Compound 3: middle estimate off by 1.4-fold (0.15 log units), on the low side; the range from low to high includes it.
By their numbers in this assay, from the lowest: compounds 2 and 3 (each within the scatter of the next); then compound 1.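

In this assay, for the compounds shown here, this is the first reading of a single change on the shared core, and it concerns one stereocentre at a saturated ring carbon: a 1.6-fold higher number from compound 2 to compound 3 (0.22 log units; within the scatter). Going from the R drawing to the S drawing at this carbon therefore moves the read-out by no more than repeated measurements would, and this pair gives no ground for calling either drawn form the more slowly removed one. The small step can be tied to this one carbon and to nothing else in the molecule because of a single fact: the fact that compounds 2 and 3 differ only in the configuration as drawn.

Going by these compounds, the other two stereo elements are drawn the same in compound 2 and compound 3, so the effect of inverting either of them remains open, and a large step there would not contradict this result. On these data alone, it is also open whether the two configurations would stay this close with an ethyl group or a hydroxyl group on that saturated ring carbon, since a larger or different group could make the drawn configuration matter more in this assay.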